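Thienopyrimidine Styryl Compounds: Nitric Oxide Inhibition in Liver Cells

The source may report more compounds than this note shows. Statements on the series, on what has been measured and on what is new or still open speak of the compounds shown alone.

Measured so far:
compound 1 `CCCc1nn(C)c2c(NC(C)C)nc(/C=C/c3nc(C)c(C)nc3C)nc12` — 342000 nM
compound 2 `CN1CCN(c2nc(/C=C/c3ccco3)nc3ccsc23)CC1` — > 1000000 nM
compound 3 `COc1cc(/C=C/c2nc(N3CCCC3)c3sccc3n2)cc(OC)c1OC` — 681000 nM

All three were tested in a functional assay on L02 cells (Homo sapiens) for inhibition, read by Griess assay, with stated times of 1 h and 24 h; a lower number here means a stronger inhibitor, a higher number a weaker inhibitor. Compound 1 gives 342000 nM. For compound 2 the assay reports only a limit, > 1000000 nM, not a number. Compound 3 gives 681000 nM, the highest of the two numbers; the nearest is compound 1, and the gap between them lies within the usual scatter, so neither can be called the weaker of the two.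

Compound 4 `COc1cc(/C=C/c2nc(Nc3ccc(O)cc3)c3sccc3n2)cc(OC)c1OC` differs from compound 3 in one place: (4-hydroxyphenyl)amino in place of pyrrolidin-1-yl on an aromatic carbon. Within the data shown here, no step between two measured compounds matches this change, so there is no measured guide to its size or direction. Compound 4 keeps the trimethoxystyryl side of compound 3 unchanged, and the expectation is that its value in this assay stays close to that of compound 3, with a step of a 1.5-fold lower number from compound 3 to compound 4 (0.18 log units; within the scatter) that is not expected to go clearly beyond the scatter. The estimate for compound 4 is 450000 nM, expected to fall between 120000 nM and 1000000 nM.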

Compound 4, half-maximal inhibitory concentration: > 1000000 nM
Compound 4 was reported as a limit; the forecaster's own chance of this, stated with the estimate: 25%; middle value at least 2.2-fold (0.34 log units) away from the limit.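

In this assay compound 4 gives > 1000000 nM as a limit of the assay and not as a number. Placing (4-hydroxyphenyl)amino in place of pyrrolidin-1-yl on this aromatic carbon, next to the ring nitrogen, gives an at least 1.4-fold higher number from compound 3 to compound 4 (0.16 log units; that floor lies within the scatter) and shows no sign of stronger inhibition, although the true size of the step remains unknown. This result offers only a floor for the change, and it is not alone in the set in resting on a limit: the limit of > 1000000 nM in this assay, at which 2 of the 4 values shown sit.

Going by these compounds, whether a morpholine ring or a small amine such as dimethylamino at this position would give a clearly lower number remains open. Also open, on these data alone, is how a plain phenylamino group, without the hydroxyl of compound 4, would read in the same test.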